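The source may hold more compounds than are shown below. What is called first, only, known or untested is meant among the compounds shown, and "the series" means these compounds.

Three analogues sharing one core have been examined in a functional assay on SK-OV-3 cells (Homo sapiens) for inhibition, read by sulforhodamine B assay, with a stated time of 48 h, tested at 10 uM; a lower number here means a stronger effect, a higher number a weaker effect of the compound at the concentration tested. Compound 1 `COc1cc(Cl)cc(-c2nn(-c3cccc(NC(=O)Nc4cccc(C(F)(F)F)c4)c3)cc2-c2ccncc2)c1` gives 14.2% in this assay. Compound 2 `COc1cc(Cl)cc(-c2nn(-c3cccc(NC(=O)c4cc(C(F)(F)F)cc(C(F)(F)F)c4)c3)cc2-c2ccncc2)c1` gives 83.4%, and compound 3 `COc1cc(Cl)cc(-c2nn(-c3cccc(NC(=O)c4ccc(Cl)c(Cl)c4)c3)cc2-c2ccncc2)c1` gives 80.1%. Among these three numbers compound 3 stands second highest; its nearest neighbour is compound 2, whose value lies within the scatter of its own, and the furthest is compound 1, whose value lies far below it, as the step of a number 65.9 percentage points higher from compound 1 to compound 3 (beyond the scatter) shows.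

Compound 4 `COc1cc(Cl)cc(-c2nn(-c3cccc(NC(=O)c4cccc(C(F)(F)F)c4)c3)cc2-c2ccncc2)c1` is the next member to be measured. It differs from compound 3 by 3-(trifluoromethyl)phenyl in place of 3,4-dichlorophenyl on a carbonyl carbon. For the measured compounds named here, no measured step mirrors this exact change. Going by the values given here, the one measured step, a number 65.9 percentage points higher from compound 1 to compound 3 (beyond the scatter), concerns the exchange of a (3-(trifluoromethyl)phenyl)amino group for a 3,4-dichlorophenyl group and is large, but it does not bear directly on a swap between two aryl groups on the carbonyl. The values of compound 2 and compound 3, both carrying an aryl carbonyl, lie within the scatter of each other. Compound 4 is therefore expected to give a step of a number 2.1 percentage points lower from compound 3 to compound 4 (within the scatter), that is none beyond the scatter. The estimate for compound 4 is 78%, with a range from 60% to 95%.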

Compound 4, a percentage reported as activity, at one concentration (the size of the read-out at that concentration, not a potency): 81.6%
Estimate against measurement, compound 4: 3.6 percentage points below; measured number inside the range.
By their numbers in this assay, from the lowest: compound 1; then compounds 3, 4 and 2 (each within the scatter of the next).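

In this assay, the aryl group on the carbonyl carbon can change with no visible consequence: the step of a number 1.5 percentage points higher from compound 3 to compound 4 (within the scatter) and, with hydrogen in place of one trifluoromethyl, the step of a number 1.8 percentage points lower from compound 2 to compound 4 (within the scatter) leave these three aryl amides indistinguishable. For the compounds shown here, compound 4 also gives the first comparison that keeps the 3-(trifluoromethyl)phenyl ring while removing only the amino link to the carbonyl, and the step of a number 67.4 percentage points higher from compound 1 to compound 4 (beyond the scatter) ties the large gap to that link rather than to the substitution on the ring. Nothing available explains this difference.

Going by these compounds alone, only one aryl group is seen on the amino link, so it remains open whether 3,4-dichlorophenyl there would match compound 1. Also open, going by these compounds, is what a methylene or an ether oxygen in place of the amino nitrogen would give.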